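Swapping Fluoro for Nitro on the Pendant Aromatic Ring

The source may hold more compounds than are shown below. What is called first, only, known or untested is meant among the compounds shown, and "the series" means these compounds.

Three close relatives share one core and differ only in the aromatic ring at the end of the double-bonded chain. Compound 1 `CC(O)Cn1c([N+](=O)[O-])cnc1/C=C/c1cccc(F)c1` carries a 3-fluorophenyl there, compound 2 `CC(O)Cn1c([N+](=O)[O-])cnc1/C=C/c1ccc(Cl)cc1` a 4-chlorophenyl and compound 3 `CC(O)Cn1c([N+](=O)[O-])cnc1/C=C/c1ccccc1F` a 2-fluorophenyl. In an ADME assay on cells (Macrophage, Homo sapiens) for cytotoxicity, read by MTT assay, with a stated time of 24 h (a lower number here means that less compound is tolerated, a higher number that more compound is tolerated), compound 1 gives 1030 nM, compound 2 gives 980 nM and compound 3 gives 1410 nM. Compound 1 stands second highest of the three, but every gap is within the scatter: a 1.1-fold lower number from compound 1 to compound 2 (0.02 log units; within the scatter), a 1.4-fold higher number from compound 1 to compound 3 (0.14 log units; within the scatter) and a 1.4-fold higher number from compound 2 to compound 3 (0.16 log units; within the scatter).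

Compound 4 `CC(O)Cn1c([N+](=O)[O-])cnc1/C=C/c1cccc([N+](=O)[O-])c1` is the next step from compound 1: nitro in place of fluoro on an aromatic carbon. For the measured compounds named here, no measured step tests a nitro group, yet all three steps, each swapping or relocating a halogen on that ring, stayed within the scatter, so this ring substituent has not moved the number so far. The expectation for compound 4 in this assay is therefore a step of a 1.0-fold higher number from compound 1 to compound 4 (0.01 log units; within the scatter), nothing beyond the scatter. Compound 4 is estimated at 1050 nM, with a range from 550 nM to 2100 nM.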

Compound 4, half-maximal cytotoxic concentration: 430 nM
For compound 4 the middle estimate is 2.4-fold (0.39 log units) above the measured one, and the stated range ends above it.
By their numbers in this assay, from the lowest: compound 4; then compounds 2, 1 and 3 (each within the scatter of the next).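

In this assay, for the compounds shown here, nitro in place of fluoro on this aromatic carbon gives a 2.4-fold lower number from compound 1 to compound 4 (0.38 log units; beyond the scatter) and so is the first change on the pendant ring to go beyond the scatter. The halogen swaps among compounds 1, 2 and 3 had suggested that this ring substituent made little difference, but compound 4 shows that the number can respond to what sits on the ring. The change swaps one heavy atom with no hydrogen-bond acceptors for three heavy atoms with two such acceptors, but nothing available explains why the number falls. A single nitro compound cannot show whether the drop is specific to nitro, so a nitrile or an amine on the same carbon remains an open case. Also open, as far as these compounds go, is whether a nitro group elsewhere on the ring would give a similar step.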